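Propoxy to isopropoxy: expected exposure of compound 3

This account rests on a few compounds, and the source may have more. Where it says the series, first, only, none or still open, it means among the compounds named here.

Of the compounds shown here, two have numbers so far in an ADME assay on the whole organism with Rattus norvegicus as the target, with a stated time of 6 h, at a dose of 10 mg/kg by the oral route; on this read-out higher numbers stand for higher exposure at the dose given and lower numbers for lower exposure. Compound 1 (`CCO/N=C(\c1ccc(Br)cc1)C1CCN(C2(C)CCN(C(=O)c3c(Cl)c[n+]([O-])cc3Cl)CC2)CC1`) gives 3900 ng.h/mL. Compound 2 (`CCCO/N=C(/c1ccc(Br)cc1)C1CCN(C2(C)CCN(C(=O)c3c(C)ncnc3C)CC2)CC1`) gives 1600 ng.h/mL, the lower of the two numbers, and its gap to compound 1 lies beyond the scatter. Going by the values given here, no measured pair isolates a single change, so the size of the next step has no direct precedent.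

Compound 3 (`Cc1ncnc(C)c1C(=O)N1CCC(C)(N2CCC(/C(=N\OC(C)C)c3ccc(Br)cc3)CC2)CC1`), not yet measured, follows from compound 2 by one change: isopropyl in place of propyl on an oxygen. This puts isopropyl in place of propyl on an oxygen whose other neighbours are: double-bonded nitrogen.

Among the compounds with values here, with the same atoms joined differently and no measured precedent, no step beyond the scatter is expected in this assay. The estimated change is small, as a 1.1-fold higher number from compound 2 to compound 3 (0.03 log units; within the scatter). The estimate for compound 3 is 1700 ng.h/mL, with an expected range of 750 ng.h/mL to 3800 ng.h/mL.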

Compound 3, area under the concentration-time curve: 2400 ng.h/mL
Beside the measured number, compound 3's estimate is 1.4-fold (0.15 log units) below it, and the stated range covers the measured number.
By their numbers in this assay, from the lowest: compounds 2, 3 and 1 (each within the scatter of the next, the first and the last beyond it).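

Single-change reading at the oxygen: in this assay, isopropyl in place of propyl on an oxygen whose other neighbours are: double-bonded nitrogen gives a 1.5-fold higher number from compound 2 to compound 3 (0.18 log units; within the scatter), so compound 2 and compound 3 cannot be told apart on this read-out. Going by these compounds alone, this is the first pair to isolate one change, and it shows that this rearrangement of the same three carbons, from a straight chain to a branched one, leaves exposure within the usual scatter. No supporting data bear on why the two compounds read alike.

Open: whether a longer chain such as butyl, or a ring such as cyclopropyl, on this oxygen would also stay within the scatter. Compound 1 differs from compound 2 and compound 3 in more than one place, so the effect of its ethyl cannot be read on its own.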